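Trimming a Methyl on the Side Chain

This account rests on a few compounds, and the source may have more. Where it says the series, first, only, none or still open, it means among the compounds named here.

Of the compounds shown here, three have been measured in an ADME assay on the whole organism (Mus musculus, strain CD1) for pharmacokinetics, read by LC-MS, with a stated time of 24 h, at a dose of 1 mg/kg by the intravenous route; on this read-out lower numbers stand for narrower distribution and higher numbers for wider distribution into tissues. Compound 2 `C[C@H](C(=O)O)n1nc(Cn2cc3cc(OCC4CC4)c(Cl)cc3n2)c2ccccc2c1=O` gives 168 L/kg, the highest of the three. Compound 1 `CCC(C(=O)O)c1nn(Cc2cn3cc(OCC4CC4)c(Cl)cc3n2)c2ccccc2c1=O` gives 60 L/kg, and compound 3 `O=C(O)Cn1nc(Cc2cn3cc(OCC4CC4)c(Cl)cc3n2)c2ccccc2c1=O` gives 21 L/kg; both gaps to compound 2 lie beyond the scatter. Compound 4 `O=C(O)Cn1nc(Cn2cc3cc(OCC4CC4)c(Cl)cc3n2)c2ccccc2c1=O` has not yet been measured. It differs from compound 2 in one place: hydrogen in place of methyl on a saturated chain carbon bound to an aromatic nitrogen and a carbonyl carbon. For the measured compounds named here, no pair with exactly this change has been measured in this assay, so the expectation rests on what compound 1 and compound 3 show. For compound 4 the number is expected to fall, with a step of a 3.1-fold lower number from compound 2 to compound 4 (0.48 log units; beyond the scatter) beyond the scatter. Compound 4 is estimated at 55 L/kg, within a range of 20 L/kg to 140 L/kg.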

Compound 4, volume of distribution at steady state: 69 L/kg
The estimate for compound 4 lay 1.3-fold (0.10 log units) below the measured number; measured number inside the range.
By their numbers in this assay, from the lowest: compound 3; then compounds 1 and 4 (each within the scatter of the next); then compound 2.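

In this assay the change from 1-carboxyethyl to carboxymethyl gives a 2.4-fold lower number from compound 2 to compound 4 (0.39 log units; beyond the scatter) and so shows that this single methyl counts by itself on this read-out. The earlier compounds shown here differ from one another in more than one place, so they could not separate this change from the others. Nothing measured here gives a reason for the step.

Still open, from the compounds shown here alone, is how a larger group on this carbon, such as a propyl chain, or a different one, such as an amine, would compare. Going by these compounds, whether the same change gives a similar step on the core of compound 1 also remains unknown.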